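Aryl Amine Swaps on a Weakly Cytotoxic Shared Core

The source may report more compounds than this note shows. Statements on the series, on what has been measured and on what is new or still open speak of the compounds shown alone.

Three compounds share one core and differ only in the aryl group on the nitrogen on the aromatic ring. Compound 1 `FC(F)(F)c1ccc(CSc2nc(Nc3cccc(Br)c3)c3ccccc3n2)cc1` carries 3-bromophenyl there and in a functional assay on MCF7 cells (Homo sapiens) for cytotoxicity, read by MTT assay, with a stated time of 72 h (a lower number here means a stronger inhibitor, a higher number a weaker inhibitor), compound 1 gives 25600 nM. Compound 2 `O=[N+]([O-])c1ccc(Nc2nc(SCc3ccc(C(F)(F)F)cc3)nc3ccccc23)cc1` carries 4-nitrophenyl and in this assay compound 2 gives 17900 nM. Compound 3 `Cc1ccc(Nc2nc(SCc3ccc(C(F)(F)F)cc3)nc3ccccc23)cc1`, with 4-methylphenyl, reaches only a limit of this assay, > 50000 nM. Going by the values given here, compound 3 is the one value sitting at the limit of > 50000 nM in this assay, at which 1 of the 3 values shown sits, so it stands without a number of its own, at the edge of what the assay reports.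

The measured steps at this position were small: a 1.4-fold lower number from compound 1 to compound 2 (0.16 log units; within the scatter), an at least 1.9-fold higher number from compound 1 to compound 3 (0.29 log units; that floor lies within the scatter), and an at least 2.7-fold higher number from compound 2 to compound 3 (0.44 log units; beyond the scatter). Compound 4 `COc1ccc(Nc2nc(SCc3ccc(C(F)(F)F)cc3)nc3ccccc23)c(OC)c1` differs from compound 3 by 2,4-dimethoxyphenyl in place of 4-methylphenyl on a nitrogen on an aromatic ring. Since every aryl exchange seen here moved this assay little, compound 4 is expected to remain near the limit, with an at least 1.2-fold lower number from compound 3 to compound 4 (0.09 log units; that floor lies within the scatter) as the expected step. Compound 4 is estimated at 40000 nM, between 12000 nM and 150000 nM, with a real chance that only a limit is reported.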

Compound 4, half-maximal inhibitory concentration: > 50000 nM
Compound 4: no number, only a limit; the forecaster's own chance of this, stated with the estimate: 55%; middle value at least 1.2-fold (0.09 log units) away from the limit.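

Compound 4 is a second compound at the limit of this assay, so 2,4-dimethoxyphenyl on this nitrogen gives no measurable number, just as 4-methylphenyl does: the limit of > 50000 nM in this assay, at which 2 of the 4 values shown sit. The step between compound 3 and compound 4 cannot be read, as both are limits and not numbers. The exchange gives an at least 2.7-fold higher number from compound 2 to compound 4 (0.44 log units; beyond the scatter), the same floor as for 4-methylphenyl, so a second aryl group now stands apart from 4-nitrophenyl, while the comparison with 3-bromophenyl gives an at least 1.9-fold higher number from compound 1 to compound 4 (0.29 log units; that floor lies within the scatter).

As far as these compounds go, how far compound 3 and compound 4 lie past the limit stays open, so the two cannot be ordered. Also open, from the compounds shown here alone, is whether a single methoxy group, a carboxylic acid or an amine on this phenyl ring would bring a measurable number in this assay.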